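A few compounds are considered here, and "the series" means these few. Any claim that something is new, unique, unknown or untested is made for them only; others in the source may bear on it.

Compound 1 `CS(=O)(=O)c1ccc(NC(=O)CSc2nnc(N3C(=O)CSC3c3cccc(Cl)c3)s2)cc1` gives 113000 nM in an ADME assay on MT4 cells (Homo sapiens) for cytotoxicity, read by MTT assay, with a stated time of 5 days; a lower number here means that less compound is tolerated, a higher number that more compound is tolerated. Compound 2 `CS(=O)(=O)c1ccc(NC(=O)CSc2nnc(N3C(=O)CSC3c3ccccc3Cl)s2)cc1` gives only a limit of the assay, >= 172000 nM, in this assay.

Compound 2 therefore stands at the limit of >= 172000 nM in this assay, at which 1 of the 2 values shown sits, so its position relative to compound 1 is known only as a floor: an at least 1.5-fold higher number from compound 1 to compound 2 (0.18 log units; that floor lies within the scatter). Compound 3 `CS(=O)(=O)c1ccc(NC(=O)CSc2nnc(N3C(=O)CSC3c3ccccc3)s2)cc1` differs from compound 2 by hydrogen in place of chloro on an aromatic carbon. Within the data shown here, the only measured step, from compound 1 to compound 2, moves the chloro from one aromatic position to another rather than removing it, and its floor lies within the scatter, so it offers no direct guide to loss of the chloro. With nothing pointing beyond the scatter, compound 3 is expected to show no change beyond the scatter from compound 2, that is an at least 1.1-fold lower number from compound 2 to compound 3 (0.05 log units; that floor lies within the scatter). Compound 3 is accordingly estimated at 150000 nM in this assay, within a range of 70000 nM to 320000 nM, with a fair chance that the assay again returns only a limit.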

Compound 3, half-maximal cytotoxic concentration: 131000 nM
For compound 3 the middle estimate is 1.1-fold (0.06 log units) above the measured one; low and high end bracket the measured number.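

Taking the chloro off the ring altogether gives, in this assay, a 1.2-fold higher number from compound 1 to compound 3 (0.06 log units; within the scatter), so for the 3-chlorophenyl group this replacement by hydrogen leaves the number within the usual scatter. Starting from the 2-chlorophenyl group, the same replacement reads as an at least 1.3-fold lower number from compound 2 to compound 3 (0.11 log units; that floor lies within the scatter). That reading is only a floor, as the value on the chlorinated side is a limit of the assay and not a number: the limit of >= 172000 nM in this assay, at which 1 of the 3 values shown sits.

The compounds shown leave open how far the true value of compound 2 lies from that of compound 3, and so whether a chloro on this carbon changes the number at all. They also leave open whether another group on this ring, such as a methoxy, an amine or a carboxylic acid, would carry the number beyond the scatter.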